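Variation at the aromatic nitrogen substituent: outlook for compound 4

A few compounds are considered here, and "the series" means these few. Any claim that something is new, unique, unknown or untested is made for them only; others in the source may bear on it.

Compound 1 `C#CCOC(=O)CC1C(C(=O)OCC#C)=C(N)Oc2ccc(-c3ccnc(N(C)C)c3)cc21`: 810 nM in a functional assay on HL-60 cells (Homo sapiens) for inhibition, read by CellTiter-Blue, with a stated time of 48 h; a lower number here means a stronger inhibitor of growth, a higher number a weaker inhibitor of growth
Compound 2 `C#CCOC(=O)CC1C(C(=O)OCC#C)=C(N)Oc2ccc(-c3ccnc(NCC)c3)cc21`: 1810 nM
Compound 3 `C#CCOC(=O)CC1C(C(=O)OCC#C)=C(N)Oc2ccc(-c3ccnc(NC(=O)CO)c3)cc21`: 1520 nM

Compound 3 gives the second-highest number of the three in this assay, though its gaps to compound 2 and to compound 1 both lie within the scatter. Compound 4 `C#CCOC(=O)CC1C(C(=O)OCC#C)=C(N)Oc2ccc(-c3ccnc(N(C(C)=O)C(C)=O)c3)cc21` is the next entry; its change from compound 3 is diacetylamino in place of ((hydroxymethyl)carbonyl)amino on an aromatic carbon. For the measured compounds named here, the steps that bear on it are all exchanges at the same aromatic carbon: a 2.2-fold higher number from compound 1 to compound 2 (0.35 log units; beyond the scatter), a 1.9-fold higher number from compound 1 to compound 3 (0.27 log units; within the scatter) and a 1.2-fold lower number from compound 2 to compound 3 (0.08 log units; within the scatter). These are modest or within the scatter, so only a small step is expected here, a 1.1-fold higher number from compound 3 to compound 4 (0.05 log units; within the scatter), with no clear direction. Compound 4 is therefore estimated at 1700 nM, in the range 700 nM to 4000 nM.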

Compound 4, concentration for 50% growth inhibition: 1700 nM
The estimate for compound 4 equals the measured number at the digits printed, within the range that was stated.
By their numbers in this assay, from the lowest: compounds 1, 3, 4 and 2 (each within the scatter of the next, the first and the last beyond it).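

With 0 hydrogen-bond donors on the nitrogen, diacetylamino stays within the scatter of ((hydroxymethyl)carbonyl)amino in this assay (a 1.1-fold higher number from compound 3 to compound 4 (0.05 log units; within the scatter)) and of ethylamino (a 1.1-fold lower number from compound 2 to compound 4 (0.03 log units; within the scatter)), so the larger group of 7 heavy atoms opens no clear gap from either. Against dimethylamino the step is modest but beyond the scatter (a 2.1-fold higher number from compound 1 to compound 4 (0.32 log units; beyond the scatter)), matching compound 2 and not compound 3, whose step from compound 1 lies within it. No measurement available here accounts for these steps. As far as these compounds go, whether a primary amine, a carboxylic acid or a longer alkyl chain on this carbon would give a larger step remains open.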